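Methoxy-to-chloro swap on the aryl ring of the shared core

A few compounds are considered here, and "the series" means these few. Any claim that something is new, unique, unknown or untested is made for them only; others in the source may bear on it.

Measured compounds:
- compound 1 `COc1ccc(/C=C2\C(=O)N(c3c(Cl)cccc3Cl)c3ccccc32)cc1OC` — < 1 ug/mL
- compound 2 `Cc1ccc2nc(Cl)c(/C=C3\C(=O)N(c4c(Cl)cccc4Cl)c4ccccc43)cc2c1` — "not determined" (no result reported)
- compound 3 `COc1ccc(/C=C2\C(=O)N(c3c(Cl)cccc3Cl)c3ccccc32)cc1` — > 100 ug/mL

In a functional assay on HuTu80 cells (Homo sapiens) for cytotoxicity, read by MTT assay, with a stated time of 72 h (a higher number here means that more compound is needed for the effect, a lower number that less compound is needed), compound 1 gives < 1 ug/mL, which is a limit of the assay and not a number (the limit of < 1 ug/mL in this assay, at which 1 of the 3 values shown sits). Compound 2 carries "not determined" (no result reported) in this assay. Compound 3 reaches > 100 ug/mL in this assay, again a limit rather than a number (the limit of > 100 ug/mL in this assay, at which 1 of the 3 values shown sits). Compound 3 therefore sits at the high edge of what is shown; the one other value shown is also a limit, and compound 2 has no number at all.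

Going by the values given here, the single measured step with numbers is an at least 100-fold higher number from compound 1 to compound 3 (2.00 log units; beyond the scatter), hydrogen in place of methoxy on an aromatic carbon. It concerns the removal of a methoxy, not an exchange for another group.

Compound 4 `O=C1/C(=C\c2ccc(Cl)cc2)c2ccccc2N1c1c(Cl)cccc1Cl` differs from compound 3 by chloro in place of methoxy on an aromatic carbon. Among the compounds with values here, no measured step exchanges methoxy for chloro, so the step from compound 1 to compound 3 bears on it only loosely, by showing that a change at a methoxy can move the number a great deal. With compound 3 itself known only as a limit, no direction can be read with confidence. Compound 4 is expected to give about 80 ug/mL in this assay, within a range of 15 ug/mL to 300 ug/mL. The step of an at least 1.2-fold lower number from compound 3 to compound 4 (0.09 log units; that floor lies within the scatter) is thus estimated to stay within the scatter, with a real chance that the assay again returns only a limit.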

Compound 4, concentration for half-maximal effect: 6 ug/mL
Compound 4: the middle estimate sits 13-fold (1.12 log units) above what was measured; measured number outside the range, below it.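

Going by these compounds alone, the 4-methoxyphenyl to 4-chlorophenyl change is the first exchange at this position, rather than a removal, and in this assay it gives an at least 16-fold lower number from compound 3 to compound 4 (1.22 log units; beyond the scatter). That size is only a floor, since the high end of the comparison is a limit and not a number: the limit of > 100 ug/mL in this assay, at which 1 of the 4 values shown sits. Both measured steps now meet at compound 3, and the number falls on leaving it either way, by a second methoxy on the ring or by chloro in place of the methoxy, so this single aromatic carbon, para to a large group, can carry a large change on the shared core.

From the compounds shown here alone, whether the lower number belongs to chloro itself or simply to the loss of the methoxy stays open, and a plain hydrogen, a fluoro, a dimethylamino group or a carboxylic acid at this position would help to separate the two. Going by these compounds, the true size of the step also stays open until compound 3 has a number rather than a limit, and compound 2, with no result, adds nothing to the reading.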